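This account rests on a few compounds, and the source may have more. Where it says the series, first, only, none or still open, it means among the compounds named here.

Measured compounds in a toxicity assay on HEK-293T cells (Homo sapiens) for cytotoxicity, read by CCK-8 assay, with a stated time of 48 h; on this read-out lower numbers stand for higher toxicity in this test and higher numbers for lower toxicity in this test:
- Compound 1 `Cn1cc(SCc2nnc(SCc3ccccc3)n2-c2c(Cl)cccc2Cl)c2ccccc21` gives > 100000 nM, which is a limit of the assay and not a number.
- Compound 2 `Cn1cc(SCc2nnc(SCc3cccc(Cl)c3Cl)n2-c2c(Cl)cccc2Cl)c2ccccc21` gives > 100000 nM, again a limit.
- Compound 3 `Cn1cc(SCc2nnc(SCc3c(Cl)cccc3Cl)n2-c2c(Cl)cccc2Cl)c2ccccc21` gives > 100000 nM, also a limit.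

Compound 3 therefore stands at the limit of > 100000 nM in this assay, at which 3 of the 3 values shown sit, together with the other two. The steps a step that the two limits leave unreadable from compound 1 to compound 2, a step that the two limits leave unreadable from compound 1 to compound 3 and a step that the two limits leave unreadable from compound 2 to compound 3 all remain unreadable, because the limit of > 100000 nM in this assay, at which 3 of the 3 values shown sit, hides any difference between them. Compound 4 `Cn1cc(SCc2nnc(SCc3cccc(Cl)c3F)n2-c2c(Cl)cccc2Cl)c2ccccc21` differs from compound 3 by 3-chloro-2-fluorophenyl in place of 2,6-dichlorophenyl on a saturated chain carbon bound to a sulfur. The measured steps that bear on this, all swaps of the ring on the same chain carbon, show no toxicity up to the limit in any case. Compound 4 is thus expected to reach the limit as well, with an estimate of 150000 nM and a range from 80000 nM to 400000 nM. The step that the limit leaves unreadable from compound 3 to compound 4 is expected to stay within the scatter.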

Compound 4, half-maximal cytotoxic concentration: > 100000 nM
Compound 4: only a limit was reported; the forecaster's own chance of this, stated with the estimate: 85%; the middle value lies beyond the limit too.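

No step among compound 1, compound 2, compound 3 and compound 4 can be read, since each result in this assay is a limit and not a number: the limit of > 100000 nM in this assay, at which 4 of the 4 values shown sit.

Going by these compounds, whether these compounds differ from one another in this assay, and at what concentration any of them would become toxic to these cells, stays open.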